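From compound 2 to compound 3: a side chain exchanged

The source may hold more compounds than are shown below. What is called first, only, known or untested is meant among the compounds shown, and "the series" means these compounds.

Measured in an ADME assay on BJ cells (Homo sapiens) for cytotoxicity, read by luminescence, with a stated time of 72 h; on this read-out higher numbers stand for an effect only at larger amounts of compound and lower numbers for an effect already at smaller amounts:
Compound 1 `COc1cc2[nH]c(-c3cccc(Oc4ccccc4)c3)c(C(=O)NCCN3CCCC3)c(=O)c2cc1F`: > 21500 nM, a limit
Compound 2 `COc1cc2[nH]c(-c3cccc(Oc4ccccc4)c3)c(C(=O)NCCCN3CCCC3)c(=O)c2cc1F`: > 21500 nM, a limit

In this assay compound 2 gives > 21500 nM, which is a limit and not a number. The whole record so far is the limit of > 21500 nM in this assay, at which 2 of the 2 values shown sit. Compound 3 `COc1cc2[nH]c(-c3cccc(Oc4ccccc4)c3)c(C(=O)OCCO)c(=O)c2cc1F` has not yet been measured. It departs from compound 2 on a carbonyl carbon, where 2-hydroxyethoxy stands in place of (3-(pyrrolidin-1-yl)propyl)amino: 2-hydroxyethoxy in place of (3-(pyrrolidin-1-yl)propyl)amino on a carbonyl carbon. Going by the values given here, the one measured step is a step that the two limits leave unreadable from compound 1 to compound 2. Among the compounds with values here, that step has no readable size and concerns a different change, so it offers nothing to carry over, and no measured compound carries the entering group. The expectation therefore rests on compound 2 alone, at > 21500 nM, and no clear move in either direction is expected in this assay. Another limit is the likeliest report. The expected change is an at least 1.0-fold lower number from compound 2 to compound 3 (0.03 log units; that floor lies within the scatter). The estimated value for compound 3 is 20000 nM, with an expected range from 8000 nM to 40000 nM.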

Compound 3, half-maximal effective concentration: > 21500 nM
Compound 3: a limit, no number; the forecaster's own chance of this, stated with the estimate: 65%; middle value at least 1.0-fold (0.03 log units) from the limit.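

Compound 3 also gives a limit and not a number in this assay, > 21500 nM, so no step between compound 1, compound 2 and compound 3 can be read, and the record stands at one value: the limit of > 21500 nM in this assay, at which 3 of the 3 values shown sit.

The compounds shown leave open where the half-maximal effective concentration of each lies and whether exchanging the side chain changes it in this assay.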